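The source may report more compounds than this note shows. Statements on the series, on what has been measured and on what is new or still open speak of the compounds shown alone.

Of the compounds shown here, three of one shared core have so far been measured in a physicochemical assay for lipophilicity, measured as octanol-water partition; a higher number here means a more lipophilic compound, a lower number a more polar compound. Compound 1 `CC1=C(C(=O)OCc2cccnc2)C(c2ccc(C#N)cc2)C2=C(CCCC2=O)N1` carries a cyano group on its phenyl ring and, in this assay, compound 1 gives 1.36, the lowest of the three numbers. Compound 3 `COc1cc(C2C(C(=O)OCc3ccccn3)=C(C)NC3=C2C(=O)CCC3)cc(OC)c1OC` gives 2.17 in this assay, a gap from compound 1 beyond the scatter. Compound 2 `CC1=C(C(=O)OCc2ccccn2)C(c2ccc(Br)cc2)C2=C(CCCC2=O)N1` gives 2.42 in this assay, again beyond the scatter from compound 1 and the widest gap of the three.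

Compound 4 `CC1=C(C(=O)OCc2cccnc2)C(c2ccc(Cl)cc2)C2=C(CCCC2=O)N1` has not yet been measured in this assay. It differs from compound 1 in one place: chloro in place of cyano on an aromatic carbon. For the measured compounds named here, no pair of measured compounds shows this exact change, so its size here cannot be read directly from the data. Still, a clear rise beyond the scatter is expected, partly because compound 2 carries bromo on its phenyl ring and gives 2.42. The step from compound 1 to compound 4 is thus estimated at a number 1.14 log units higher from compound 1 to compound 4 (beyond the scatter). Compound 4 is therefore expected to give about 2.5 in this assay, within a range of 2.1 to 2.9.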

Compound 4, partition coefficient: 1.87
Beside the measured number, compound 4's estimate is 0.63 log units above it; the measured number lies below the stated range.
By their numbers in this assay, from the lowest: compound 1; then compounds 4, 3 and 2 (each within the scatter of the next, the first and the last beyond it).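

For the compounds shown here, with the rest of the molecule unchanged, going from 4-cyanophenyl to 4-chlorophenyl gives the first change at a single place that can be read directly, and the result is a number 0.51 log units higher from compound 1 to compound 4 (beyond the scatter) in this assay for this pair. This position on the phenyl ring therefore does respond to this swap, although the step is only modest. Nothing available accounts for the size of the step.

Going by these compounds alone, compounds 2 and 3 differ from compound 1 in more than one place, so no further steps at this position can be read from them. On these data alone, it remains open how an amine, a carboxylic acid or a methyl group would fare at this position, and whether the same swap gives a similar step with the ester side chain of compounds 2 and 3.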